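Para-substituted phenyl replacing naphthalen-1-yl on the shared core

The compounds below may be only part of what the source reports. "The series", "measured", "known", "first", "only" and "open" are said of these compounds alone.

Measured so far in a functional assay on NCI-H460 cells (Homo sapiens) for inhibition, read by sulforhodamine B assay, with a stated time of 48 h, tested at 10 uM; a higher number here means more inhibition at the concentration tested (going by the name of the read-out), a lower number less inhibition:
- compound 1 `c1ccc(-c2cn3ccnc3c(-c3ccc4ncn(C5CCCCC5)c4c3)n2)cc1`: 37.8%
- compound 2 `COc1ccc(-c2cn3ccnc3c(-c3ccc4ncn(C5CCCCC5)c4c3)n2)cc1`: 91.1%
- compound 3 `c1ccc2c(-c3cn4ccnc4c(-c4ccc5ncn(C6CCCCC6)c5c4)n3)cccc2c1`: 3.61%

Compound 3 gives the lowest inhibition of the three. Its nearest neighbour is compound 1, and the gap is a number 34.2 percentage points lower from compound 1 to compound 3 (beyond the scatter); the furthest is compound 2, with a number 87.5 percentage points lower from compound 2 to compound 3 (beyond the scatter). Both gaps lie beyond the scatter.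

Compound 4 `Fc1ccc(-c2cn3ccnc3c(-c3ccc4ncn(C5CCCCC5)c4c3)n2)cc1` is not yet measured. The change from compound 3 is 4-fluorophenyl in place of naphthalen-1-yl on an aromatic carbon.

Within the data shown here, two measured steps bear on this. The reverse of a number 34.2 percentage points lower from compound 1 to compound 3 (beyond the scatter) shows what removing the second carbon ring returns, and a number 53.3 percentage points higher from compound 1 to compound 2 (beyond the scatter) shows that a group in the same position of the phenyl ring as the fluorine, namely methoxy, raised inhibition by a large amount. Whether fluorine acts like methoxy or like hydrogen is not shown by any measured pair; compound 1 gives 37.8% and compound 2 gives 91.1%, so these two bracket the likely outcome.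

A large rise is therefore expected, a number 46.4 percentage points higher from compound 3 to compound 4 (beyond the scatter). Compound 4 is estimated at 50%, with a range from 25% to 80%.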

Compound 4, a percentage reported as inhibition, at one concentration (the size of the read-out at that concentration, not a potency): 6.12%
Estimate against measurement, compound 4: 43.9 percentage points above; measured number below the stated range.
By their numbers in this assay, from the lowest: compounds 3 and 4 (each within the scatter of the next); then compound 1; then compound 2.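

In this assay, fluoro in place of hydrogen gives a number 31.7 percentage points lower from compound 1 to compound 4 (beyond the scatter), so a substituent on the phenyl ring does not in itself raise inhibition, and methoxy and fluoro move the number in opposite directions from compound 1. Fluoro in place of methoxy gives a number 85 percentage points lower from compound 2 to compound 4 (beyond the scatter), which leaves methoxy as the only phenyl substituent shown that gives a gain. 4-Fluorophenyl in place of naphthalen-1-yl gives a number 2.5 percentage points higher from compound 3 to compound 4 (within the scatter), so this replacement recovers nothing at this position, although the unsubstituted phenyl of compound 1 stands clearly above both. No measurement shown explains these differences.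

On these data alone, whether the gain is particular to methoxy remains open; hydroxy, ethoxy or dimethylamino on the same phenyl position would test this. These single-concentration read-outs also leave the potency of compound 2 undefined.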